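This account rests on a few compounds, and the source may have more. Where it says the series, first, only, none or still open, it means among the compounds named here.

Two compounds share a core in which an aryl group sits on a five-membered aromatic ring with two nitrogens. Compound 1 `O=C(/C=C/c1cccc(O)c1)c1cccc(-n2cc(-c3ccc(Cl)cc3)[nH]c2=O)c1` is one of them; in a functional assay on OVCAR-3 cells (Homo sapiens) for inhibition (a lower number here means a stronger inhibitor of growth, a higher number a weaker inhibitor of growth), compound 1 gives 1560 nM. Compound 2 `COc1cc(/C=C/C(=O)c2cccc(-n3cc(-c4ccccc4)[nH]c3=O)c2)cc(OC)c1OC` is the other; in this assay compound 2 gives 1230 nM. Within the data shown here, because these two differ in more than one place, no single step between them has been counted, and their two numbers lie within the usual scatter of each other, so nothing separates them on these data.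

Compound 3 `COc1cc(/C=C/C(=O)c2cccc(-n3cc(-c4cc(OC)c(OC)c(OC)c4)[nH]c3=O)c2)cc(OC)c1OC` has not yet been measured. It differs from compound 2 in one place only: 3,4,5-trimethoxyphenyl in place of phenyl on an aromatic carbon. Among the measured compounds shown here, no measured pair shows what this exchange does, so the expectation rests on the change itself and on where compound 2 stands. A modest move toward stronger growth inhibition is expected, though one that may not reach beyond the scatter. Compound 3 is expected to give 700 nM, with a range from 250 nM to 2500 nM. The estimated step of a 1.8-fold lower number from compound 2 to compound 3 (0.24 log units; within the scatter) is therefore expected to be small.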

Compound 3, concentration for 50% growth inhibition: 1480 nM
For compound 3 the middle estimate is 2.1-fold (0.33 log units) below the measured one, and the stated range covers the measured number.
By their numbers in this assay, from the lowest: compounds 2, 3 and 1 (each within the scatter of the next).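

Among these compounds, putting 3,4,5-trimethoxyphenyl in place of phenyl gives the first direct reading of this position, the aromatic carbon of the five-membered ring, in this assay: the exchange comes out as a 1.2-fold higher number from compound 2 to compound 3 (0.08 log units; within the scatter), so compound 2 and compound 3 cannot be told apart. The entering group has 12 heavy atoms against the 6 of phenyl and 3 hydrogen-bond acceptors against none, so for this one pair, a much larger aryl group with these added oxygens leaves the growth-inhibition number within the scatter. Nothing measured here accounts for this result.

One exchange at one position cannot show whether the position is insensitive to all changes or only to this one, and it cannot separate the effect of the three methoxy groups from one another, so a single methoxy, an amine or a carboxylic acid on this aryl ring remains an open test. Compound 1 differs from the others in more than one place, so what its chlorine does on this same ring also stays unresolved.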